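An aryl swap on the ring nitrogen of compound 3

The source may report more compounds than this note shows. Statements on the series, on what has been measured and on what is new or still open speak of the compounds shown alone.

The measured compounds are few. Compound 1 `N#CC1=C(N)Oc2c(c3nc4ccccc4nc3c3ccccc23)C12C(=O)N(Cc1cnnn1-c1ccc(Cl)cc1)c1ccccc12` is measured in an ADME assay on HUVEC cells (Homo sapiens) for antiproliferative activity, read by MTT assay, with a stated time of 48 h; on this read-out lower numbers stand for stronger inhibition and higher numbers for weaker inhibition. Compound 1 gives a limit of the assay, > 50000 nM. Compound 2 `N#CC1=C(N)Oc2c(c3nc4ccccc4nc3c3ccccc23)C12C(=O)N(Cc1cnnn1-c1ccccc1Br)c1ccccc12` gives likewise only a limit, > 50000 nM. Compound 3 `N#CC1=C(N)Oc2c(N)cc3nc4ccccc4nc3c2C12C(=O)N(Cc1cnnn1-c1cccc(Br)c1)c1ccccc12` also gives a limit, > 50000 nM.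

Within the data shown here, the one step that can be laid beside these structures, a step that the two limits leave unreadable from compound 1 to compound 2, stays unreadable: neither end of it is a number. Among the measured compounds shown here, compound 3 therefore stands where all three stand, on the limit (the limit of > 50000 nM in this assay, at which 3 of the 3 values shown sit), with no number of its own and no step to lean on.

Compound 4 `CCc1cccc(CC)c1-n1nncc1CN1C(=O)C2(C(C#N)=C(N)Oc3c(N)cc4nc5ccccc5nc4c32)c2ccccc21` has not been measured. It differs from compound 3 by 2,6-diethylphenyl in place of 3-bromophenyl on an aromatic nitrogen. For the measured compounds named here, no measured step touches this change, so nothing beyond the scatter is expected in this assay in either direction, and compound 4 is expected to reach only the limit again. The step from compound 3 to compound 4 is thus estimated as a step that the limit leaves unreadable from compound 3 to compound 4. Compound 4 is estimated at 70000 nM, with a range from 25000 nM to 250000 nM.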

Compound 4, half-maximal inhibitory concentration: > 50000 nM
Compound 4: a limit, no number; the forecaster's own chance of this, stated with the estimate: 80%; the middle value does not contradict the limit.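

Compound 3 and compound 4 both give only a limit in this assay, not a number, so the step between them cannot be read. The compounds shown leave open whether changing the aryl group on the ring nitrogen alters activity at all, since every value stands on the same limit: the limit of > 50000 nM in this assay, at which 4 of the 4 values shown sit.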